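The source may report more compounds than this note shows. Statements on the series, on what has been measured and on what is new or still open speak of the compounds shown alone.

Measured in a functional assay on HCT-116 cells (Homo sapiens) for cytotoxicity, read by sulforhodamine B assay, with a stated time of 24 h; a higher number here means a weaker inhibitor, a lower number a stronger inhibitor:
compound 1 `N/N=C1\C(=O)Nc2ccc(S(=O)(=O)N3CCOCC3)cc21`, 36300 nM
compound 2 `O=C1Nc2ccc(S(=O)(=O)N3CCOCC3)cc2/C1=N/c1cccc(C(F)(F)F)c1`, 15900 nM
compound 3 `O=C1Nc2ccc(S(=O)(=O)N3CCOCC3)cc2/C1=N/c1ccc(Cl)cc1`, 24300 nM

Compound 3 gives the second highest of the three numbers, but it sits within the scatter of compound 1 (a 1.5-fold lower number from compound 1 to compound 3 (0.17 log units; within the scatter)) and of compound 2 (a 1.5-fold higher number from compound 2 to compound 3 (0.18 log units; within the scatter)), so no order among the three is secure. Going by the values given here, the only step beyond the scatter is a 2.3-fold lower number from compound 1 to compound 2 (0.36 log units; beyond the scatter).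

Compound 4 `CC(=O)N/N=C1\C(=O)Nc2ccc(S(=O)(=O)N3CCOCC3)cc21` differs from compound 3 by acetamido in place of 4-chlorophenyl on a double-bonded nitrogen. The step that bears most on this is a 1.5-fold lower number from compound 1 to compound 3 (0.17 log units; within the scatter): the same position, exchanged between amino and an aryl group, and it stayed within the scatter. The reverse move, back to a nitrogen-linked group, is therefore expected to shift little. The estimate for compound 4 is 30000 nM (range 12000 nM to 80000 nM), meaning an expected step of a 1.2-fold higher number from compound 3 to compound 4 (0.09 log units; within the scatter), not beyond the scatter.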

Compound 4, half-maximal inhibitory concentration: 29000 nM
The estimate for compound 4 lay 1.0-fold (0.01 log units) above the measured number; measured number inside the range.
By their numbers in this assay, from the lowest: compounds 2, 3, 4 and 1 (each within the scatter of the next, the first and the last beyond it).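

On the double-bonded nitrogen, acetamido, which has no ring, stays within the scatter of both aryl groups in this assay (a 1.2-fold higher number from compound 3 to compound 4 (0.08 log units; within the scatter); a 1.8-fold higher number from compound 2 to compound 4 (0.26 log units; within the scatter)). Acetyl in place of hydrogen on the amine nitrogen also stays within the scatter (a 1.3-fold lower number from compound 1 to compound 4 (0.10 log units; within the scatter)). A ring at this position is therefore not needed to keep the number within the scatter of the aryl compounds.

As far as these compounds go, whether an amine, a carboxylic acid or a longer chain in place of acetyl would move the number beyond the scatter remains open. No measured evidence here accounts for these numbers.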